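The source may report more compounds than this note shows. Statements on the series, on what has been measured and on what is new or still open speak of the compounds shown alone.

Among the measured compounds shown here, in a functional assay on MDA-MB-231 cells (Homo sapiens) for antiproliferative activity, read by MTT assay, with a stated time of 24 h (on this read-out lower numbers stand for stronger inhibition and higher numbers for weaker inhibition), compound 1 `O=C(O)CC(NC(=O)c1ccc(F)cc1)c1ccccc1F` gives 72300 nM as the only actual number so far. Compound 2 `O=C(O)CC(NC(=O)c1cccc(Br)c1)c1ccccc1F` is reported as > 100000 nM which is a limit of the assay and not a number. For the measured compounds named here, the step between these two compounds carries 3-bromophenyl in place of 4-fluorophenyl on a carbonyl carbon, and it amounts to an at least 1.3-fold higher number from compound 1 to compound 2 (0.14 log units; that floor lies within the scatter) as the only measured guide. Compound 3 `O=C(O)CC(NC(=O)c1ccc(C(F)(F)F)cc1)c1ccccc1F` keeps the core of compound 1 and has trifluoromethyl in place of fluoro on an aromatic carbon, para to a large group: trifluoromethyl in place of fluoro on an aromatic carbon is the full count of that change. Going by the values given here, no measured step makes this same exchange, so the guide is indirect. From compound 2 and its step of an at least 1.3-fold higher number from compound 1 to compound 2 (0.14 log units; that floor lies within the scatter) no clear size or direction can be drawn, and no step beyond the scatter is expected in this assay for compound 3. The expected change is a 1.2-fold higher number from compound 1 to compound 3 (0.07 log units; within the scatter) on this reasoning. For compound 3 the estimated value is 85000 nM with an expected range from 40000 nM to 170000 nM as the likely span.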

Compound 3, half-maximal inhibitory concentration: 59200 nM
The estimate for compound 3 lay 1.4-fold (0.16 log units) above the measured number, and the stated range covers the measured number.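

In this assay, trifluoromethyl in place of fluoro on an aromatic carbon, para to a large group, gives a 1.2-fold lower number from compound 1 to compound 3 (0.09 log units; within the scatter), so this exchange leaves the read-out unchanged within the usual scatter. This is a direct reading at this position, and it shows that a group with more heavy atoms than fluoro can sit there without a step beyond the scatter, at least for this one pair. Compound 2 is reported only as a limit of the assay and not as a number, so the earlier compounds gave no step of firm size or direction: the limit of > 100000 nM in this assay, at which 1 of the 3 values shown sits.

From the compounds shown here alone, since only fluoro and trifluoromethyl have been compared at this position, it remains open whether an amine, a hydroxyl group or a methoxy group there would move the number beyond the scatter in either direction. Going by these compounds, it is also open whether trifluoromethyl in place of fluoro would stay as quiet if the rest of the core of compound 1 were changed, for example if the fluoro on the other ring gave way to a methyl group.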